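The source may hold more compounds than are shown below. What is called first, only, known or untested is meant among the compounds shown, and "the series" means these compounds.

Measured compounds:
- compound 1 `c1csc(-c2cn3ccnc3c(-c3ccc4ncn(C5CCCCC5)c4c3)n2)c1`: 8.05%
- compound 2 `c1cn2cc(-c3ccc4c(c3)ncn4C3CCCCC3)nc(-c3ccc4ncn(C5CCCCC5)c4c3)c2n1`: 36.8%

Two compounds have been run in a functional assay on SK-MEL-5 cells (Homo sapiens) for inhibition, read by sulforhodamine B assay, with a stated time of 48 h, tested at 10 uM; on this read-out lower numbers stand for less inhibition and higher numbers for more inhibition at the one concentration tested (going by the name of the read-out). Compound 1 `c1csc(-c2cn3ccnc3c(-c3ccc4ncn(C5CCCCC5)c4c3)n2)c1` gives 8.05% and compound 2 `c1cn2cc(-c3ccc4c(c3)ncn4C3CCCCC3)nc(-c3ccc4ncn(C5CCCCC5)c4c3)c2n1` gives 36.8%, so compound 2 stands highest of the two numbers, with compound 1 sitting well below it, beyond the usual scatter. Among the measured compounds shown here, no step between compounds differing in one place has been recorded, so nothing in the measured pair speaks directly to the change now in hand.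

Compound 3 `c1ccc(Cn2cnc3ccc(-c4nc(-c5ccc6c(c5)ncn6C5CCCCC5)cn5ccnc45)cc32)cc1` differs from compound 2 by benzyl in place of cyclohexyl on an aromatic nitrogen. For the measured compounds named here, with no comparable step measured, the size of the effect in this assay is open; the working expectation is no shift beyond the scatter, in either direction. Compound 3 is therefore estimated at 32%, with a range from 12% to 55%. That estimate means an expected step of a number 4.8 percentage points lower from compound 2 to compound 3 (within the scatter).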

Compound 3, a percentage reported as inhibition, at one concentration (the size of the read-out at that concentration, not a potency): -84%
The estimate for compound 3 lay 116 percentage points above the measured number; the measured number lies below the stated range.
By their numbers in this assay, from the lowest: compound 3; then compound 1; then compound 2.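

The group on this aromatic nitrogen is not a neutral handle in this assay: benzyl in place of cyclohexyl gives a number 120.8 percentage points lower from compound 2 to compound 3 (beyond the scatter), even though each group brings one six-membered ring of carbon only and neither carries a hydrogen-bond donor or acceptor. The read-out also crosses zero, with compound 3 at -84% in this assay, so this change does more than remove the inhibition seen with compound 2. Nothing at hand accounts for a step of this size.

From the compounds shown here alone, it remains open whether the step follows from the aromatic ring of benzyl or from the carbon linking that ring to the nitrogen. Phenyl, a longer alkyl chain or a chain ending in an amine on this nitrogen would help separate these readings.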